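The source may report more compounds than this note shows. Statements on the series, on what has been measured and on what is new or still open speak of the compounds shown alone.

Measured so far:
compound 1 `CCCS(=O)(=O)Nc1cccc2c1CCC2c1ncc[nH]1` — 54%
compound 2 `COc1c(Cl)ccc2c1CCC2c1ncc[nH]1` — 24%
compound 3 `Cc1ccc2c(c1NS(C)(=O)=O)CCC2c1ncc[nH]1` — 83%

In a functional assay on CHO cells for agonist activity at Alpha-1A adrenergic receptor (Homo sapiens), read by FLIPR and calcium flux (a higher number here means a larger maximal response, a lower number a smaller maximal response), compound 2 gives 24%, the lowest of the three numbers. The nearest is compound 1 with 54%, a gap beyond the scatter; the furthest is compound 3 with 83%, also beyond the scatter. Compound 4 `Clc1ccc2c(c1-c1ccn[nH]1)CCC2c1ncc[nH]1` has not been measured. Against compound 2 the change is 1H-pyrazol-5-yl in place of methoxy on an aromatic carbon. Among the compounds with values here, no pair of measured compounds differs in one place only, so the size of such a step cannot be read off directly. Within the data shown here, what the series does show is that compound 1 and compound 3, each carrying a hydrogen-bond donor on the shared core, stand above compound 2, whose substituent at this place carries none; with only three compounds this is an observation, not a rule. On that basis an upward step beyond the scatter is expected, roughly to the middle of the measured spread, with wide uncertainty in either direction. The estimate implies a step of a number 31 percentage points higher from compound 2 to compound 4 (beyond the scatter). Compound 4 is expected to reach about 55%, with a range from 25% to 85%.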

Compound 4, largest response reached (Emax), in percent of the reference or control that the assay uses: 40%
Compound 4: the middle estimate sits 15 percentage points above what was measured; measured number inside the range.
By their numbers in this assay, from the lowest: compound 2; then compound 4; then compound 1; then compound 3.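

In this assay the series now has its first step at a single place: 1H-pyrazol-5-yl in place of methoxy on an aromatic carbon, ortho to a chloro group, gives a number 16 percentage points higher from compound 2 to compound 4 (beyond the scatter) and shows that this position can take an aromatic ring with a hydrogen-bond donor without loss of maximal response. The step is modest, and the change alters ring content, heavy-atom count and donor count together, so the data cannot assign the rise to any one of these. Nothing measured on hand accounts for the size of this step.

Open, from the compounds shown here alone, is whether an amine or a carboxylic acid at this place would move the response in the same direction. Also open, going by these compounds, is whether the step would hold with a methyl group in place of the chloro group.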